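Heteroaryl swaps on the ring amine of a benzofuranone series

The source may report more compounds than this note shows. Statements on the series, on what has been measured and on what is new or still open speak of the compounds shown alone.

Measured compounds:
compound 1, `COc1cnc(N2CCC(CCCNc3ccc4c(c3)OCC4=O)CC2)nc1`: 115 nM
compound 2, `COC(=O)c1cnc(N2CCC(CCCNc3ccc4c(c3)OCC4=O)CC2)nc1`: 149 nM
compound 3, `CC(C)c1nc(N2CCC(CCCNc3ccc4c(c3)OCC4=O)CC2)no1`: 161 nM

All three were tested in a functional assay on CHO-K1 cells for agonist activity at Glucose-dependent insulinotropic receptor (Homo sapiens), read by HTRF and cAMP accumulation, with a stated time of 30 min; a higher number here means that more compound is needed for the effect, a lower number that less compound is needed. Compound 3 gives the highest of the three numbers, but the distance is small: a 1.4-fold higher number from compound 1 to compound 3 (0.15 log units; within the scatter) and a 1.1-fold higher number from compound 2 to compound 3 (0.03 log units; within the scatter). The closest neighbour is compound 2, the farthest compound 1, and neither gap is beyond the scatter. The step of a 1.3-fold higher number from compound 1 to compound 2 (0.11 log units; within the scatter) is likewise within the scatter, so the three values read as one level.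

The next compound, compound 4, `CC(C)c1nsc(N2CCC(CCCNc3ccc4c(c3)OCC4=O)CC2)n1`, has not yet been measured. It differs from compound 3 at one place:
3-isopropyl-1,2,4-thiadiazol-5-yl in place of 5-isopropyl-1,2,4-oxadiazol-3-yl on an amine nitrogen in a ring

Within the data shown here, the steps that bear on this are the two earlier exchanges at the same amine nitrogen in a ring, from compound 1 and from compound 2 to compound 3, and both stayed within the scatter. Among the measured compounds shown here, nothing among the measured compounds separates the present heteroaryl groups from one another, so no step beyond the scatter is expected in this assay in either direction. For compound 4 the estimated step is a 1.0-fold lower number from compound 3 to compound 4 (0.00 log units; within the scatter), and the value is expected at 160 nM, within 80 nM to 320 nM.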

Compound 4, half-maximal effective concentration: 121 nM
For compound 4 the middle estimate is 1.3-fold (0.12 log units) above the measured one; the range from low to high includes it.
By their numbers in this assay, from the lowest: compounds 1, 4, 2 and 3 (each within the scatter of the next).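

In this assay, a 1.3-fold lower number from compound 3 to compound 4 (0.12 log units; within the scatter) shows that replacing the ring oxygen of the oxadiazole with sulfur, together with the altered attachment implied by the two group names, leaves the value on the amine nitrogen in a ring at the same level. Compound 4 also stays level with the pyrimidines, with a 1.2-fold lower number from compound 2 to compound 4 (0.09 log units; within the scatter) and a 1.1-fold higher number from compound 1 to compound 4 (0.02 log units; within the scatter), so a sulfur-containing five-membered aromatic ring now joins the two pyrimidines and the oxadiazole on this one level, and the flat picture at this position extends to four different groups. No measurement is at hand that would explain this flatness.

The compounds shown do not establish how far this tolerance reaches, since every group here is an aromatic ring carrying a small substituent and no step at this position has yet left the scatter. Going by these compounds, whether a carboxylic acid or an amine on the pyrimidine, a longer chain in place of the isopropyl group, or a simple acyl group on the ring nitrogen would hold this level remains open.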